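A Methyl Added to Compound 2

The source may hold more compounds than are shown below. What is called first, only, known or untested is meant among the compounds shown, and "the series" means these compounds.

compound 1 `Cc1ccc2c(O)cc(-c3cccc(Cl)c3)nc2n1` gives 22.9 nM
compound 2 `Cc1cccc(-c2cc(O)c3ccc(C)nc3n2)c1` gives 60.3 nM
compound 3 `Oc1cc(-c2ccc3ccccc3c2)nc2ncccc12` gives 9120 nM

In a functional assay on SF-295 cells (Homo sapiens) for antiproliferative activity (on this read-out lower numbers stand for stronger inhibition of growth and higher numbers for weaker inhibition of growth), compound 2 gives 60.3 nM and holds the second highest of the three numbers, with compound 1 a little lower and compound 3 far higher. Compound 4 `Cc1cccc(-c2cc(O)c3c(C)cc(C)nc3n2)c1` differs from compound 2 by methyl in place of hydrogen on an aromatic carbon in one place: a methyl in place of hydrogen on an aromatic carbon, opposite the ring nitrogen and meta to a methyl group.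

Among the compounds with values here, no measured pair shows this change directly. Within the data shown here, the one measured single-place step is a 2.6-fold higher number from compound 1 to compound 2 (0.42 log units; beyond the scatter) and it is modest, but it swaps chloro for methyl, so it offers only a rough guide to size. Compound 3 at 9120 nM shows that numbers in this small set can climb far, so the uncertainty leans upward. The expected result is somewhat weaker growth inhibition in this assay with an estimated 2.5-fold higher number from compound 2 to compound 4 (0.40 log units; beyond the scatter) as the step. For compound 4 the estimate is 150 nM with an expected range from 30 nM to 900 nM as its ends.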

Compound 4, concentration for 50% growth inhibition: 64600 nM
For compound 4 the middle estimate is 430-fold (2.63 log units) below the measured one; the whole stated range lies below it.
By their numbers in this assay, from the lowest: compound 1; then compound 2; then compound 3; then compound 4.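

In this assay, a single methyl in place of hydrogen on the aromatic carbon opposite the ring nitrogen gives a 1100-fold higher number from compound 2 to compound 4 (3.03 log units; beyond the scatter) and so far exceeds the modest chloro-to-methyl swap elsewhere in the molecule, a 2.6-fold higher number from compound 1 to compound 2 (0.42 log units; beyond the scatter) by comparison. This position is therefore highly sensitive: adding one heavy atom here takes a compound with strong growth inhibition to one with very weak growth inhibition. Nothing available explains why this small change has so large an effect.

The compounds shown leave open whether any group can sit at this carbon, since a fluorine, a hydroxyl, an amine or a longer chain such as ethyl could each behave differently from methyl. They also leave open whether the same methyl would cause a similar loss on the chloro-bearing compound 1.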